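A few compounds are considered here, and "the series" means these few. Any claim that something is new, unique, unknown or untested is made for them only; others in the source may bear on it.

Compound 1 `COc1cccc(/C=C2\CCC/C(=C\c3cccc(Cl)c3)C2=O)c1OC` in a functional assay on MCF7 cells (Homo sapiens) for cytotoxicity, read by MTT assay, with a stated time of 72 h (on this read-out lower numbers stand for stronger inhibition and higher numbers for weaker inhibition), gives 12000 nM, the highest of the two numbers measured, though its step to compound 2 lies within the scatter. Compound 2 `COc1cccc(/C=C2\CCC/C(=C\c3ccccc3Br)C2=O)c1OC` gives 9700 nM; the step between them is a 1.2-fold lower number from compound 1 to compound 2 (0.09 log units; within the scatter). Compound 3 `COc1cccc(/C=C2\CCC/C(=C\c3ccc(Cl)c(Cl)c3)C2=O)c1OC` is not yet measured and differs from compound 1 by chloro in place of hydrogen on an aromatic carbon. Among the measured compounds shown here, the single measured step exchanges one substituted phenyl for another rather than adding a chloro, so it bears only loosely on this change, and it was small. A step within the scatter is therefore expected, a 1.2-fold lower number from compound 1 to compound 3 (0.08 log units; within the scatter). For compound 3 the estimate in this assay is 10000 nM, with a range from 4000 nM to 30000 nM.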

Compound 3, half-maximal inhibitory concentration: 9000 nM
Beside the measured number, compound 3's estimate is 1.1-fold (0.05 log units) above it, and the stated range covers the measured number.
By their numbers in this assay, from the lowest: compounds 3, 2 and 1 (each within the scatter of the next).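

In this assay, chloro in place of hydrogen on the aromatic carbon para to a large group gives a 1.3-fold lower number from compound 1 to compound 3 (0.12 log units; within the scatter) and so adds a second chloro to the ring without a step beyond the scatter. The exchange of 2-bromophenyl for 3,4-dichlorophenyl, a 1.1-fold lower number from compound 2 to compound 3 (0.03 log units; within the scatter), also stays within it, so these three halogen patterns cannot be told apart here. No available evidence bears on this flat result. Still open, from the compounds shown here alone, is whether an amine or a carboxylic acid at this aromatic carbon would move the number beyond the scatter.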